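The compounds below may be only part of what the source reports. "The series", "measured", "known", "first", "only" and "open" are said of these compounds alone.

Working notes on the series. The shared core carries a five-membered aromatic ring with one nitrogen and one sulfur, and the three measured compounds differ only in that ring and its substituent. Compound 1 `COc1ccc2c(O[C@H]3C[C@H]4C(=O)N(C)CCCC/C=C/[C@@H]5C[C@@]5(C(=O)NS(=O)(=O)C5(C)CC5)NC(=O)N4C3)cc(-c3nc(C(C)C)cs3)nc2c1Cl` gives 48500 nM in an ADME assay on Huh-7 cells (Homo sapiens) for cytotoxicity, read by colorimetric assay; a higher number here means that more compound is tolerated, a lower number that less compound is tolerated. Compound 2 `COc1ccc2c(O[C@H]3C[C@H]4C(=O)N(C)CCCC/C=C/[C@@H]5C[C@@]5(C(=O)NS(=O)(=O)C5(C)CC5)NC(=O)N4C3)cc(-c3nc(C4CCC4)cs3)nc2c1Cl` gives 75000 nM in this assay, the step of a 1.5-fold higher number from compound 1 to compound 2 (0.19 log units; within the scatter). Compound 3 `COc1ccc2c(O[C@H]3C[C@H]4C(=O)N(C)CCCC/C=C/[C@@H]5C[C@@]5(C(=O)NS(=O)(=O)C5(C)CC5)NC(=O)N4C3)cc(-c3csc(C(C)C)n3)nc2c1Cl` gives 30200 nM in this assay and sits at the low end of the three numbers: the step of a 1.6-fold lower number from compound 1 to compound 3 (0.21 log units; within the scatter), the step of a 2.5-fold lower number from compound 2 to compound 3 (0.40 log units; beyond the scatter).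

Compound 4 `COc1ccc2c(O[C@H]3C[C@H]4C(=O)N(C)CCCC/C=C/[C@@H]5C[C@@]5(C(=O)NS(=O)(=O)C5(C)CC5)NC(=O)N4C3)cc(-c3csc(C(F)(F)F)n3)nc2c1Cl` differs from compound 3 by trifluoromethyl in place of isopropyl on an aromatic carbon, on an aromatic carbon of the five-membered ring, next to the ring nitrogen and next to the ring sulfur. Within the data shown here, no measured step swaps isopropyl for trifluoromethyl anywhere. Among the measured compounds shown here, the only measured change of the substituent on that ring is a 1.5-fold higher number from compound 1 to compound 2 (0.19 log units; within the scatter), which stayed within the scatter; the ring attachment changes a 1.6-fold lower number from compound 1 to compound 3 (0.21 log units; within the scatter) and a 2.5-fold lower number from compound 2 to compound 3 (0.40 log units; beyond the scatter) gave at most a modest shift. The step of a 1.0-fold lower number from compound 3 to compound 4 (0.00 log units; within the scatter) is therefore expected to stay within the scatter, with no clear direction. Compound 4 is estimated at 30000 nM in this assay, within a range of 12000 nM to 75000 nM.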

Compound 4, half-maximal cytotoxic concentration: 59000 nM
Compound 4: the middle estimate sits 2.0-fold (0.29 log units) below what was measured; the measured number falls inside the stated range.
By their numbers in this assay, from the lowest: compounds 3, 1, 4 and 2 (each within the scatter of the next, the first and the last beyond it).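

In this assay, among these compounds, trifluoromethyl in place of isopropyl, on the aromatic carbon next to the ring nitrogen and next to the ring sulfur, gives the first measured step that swaps this substituent for one bearing fluorine: a 2.0-fold higher number from compound 3 to compound 4 (0.29 log units; within the scatter), so at this position the swap is tolerated with no step beyond the scatter. The 2-(trifluoromethyl)-1,3-thiazol-4-yl ring also cannot be separated from either 1,3-thiazol-2-yl compound, with a 1.2-fold higher number from compound 1 to compound 4 (0.09 log units; within the scatter) and a 1.3-fold lower number from compound 2 to compound 4 (0.10 log units; within the scatter), so compound 4 lies within the scatter of all three earlier compounds, even though compound 2 and compound 3 stand apart by a 2.5-fold lower number from compound 2 to compound 3 (0.40 log units; beyond the scatter). Nothing at hand accounts for the step, and no cause can be given for it.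

Open, as far as these compounds go, is whether a group of a different kind on this carbon, such as an amine or a carboxylic acid, would also stay within the scatter in this assay. Also open, from the compounds shown here alone, is whether trifluoromethyl in place of isopropyl on the core of compound 1, with its other ring attachment, would give a step of similar size.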